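The source may report more compounds than this note shows. Statements on the series, on what has been measured and on what is new or still open speak of the compounds shown alone.

Working notes on the series. Compound 1 is `C/C=C/C(=O)Nc1cccc(Oc2nc(Nc3ccn(C)n3)nc3c2CSCC3)c1` and compound 2 is `CC/C=C/C(=O)Nc1cccc(Oc2nc(Nc3ccn(C)n3)nc3c2CSCC3)c1`, which carries methyl in place of hydrogen on a saturated chain carbon bound to a double-bonded chain carbon. In a functional assay on MCF7 cells (Homo sapiens) for antiproliferative activity, read by MTT assay, with a stated time of 72 h (a higher number here means a weaker inhibitor, a lower number a stronger inhibitor), compound 1 gives 40000 nM. In this assay compound 2 gives > 50000 nM, which is a limit of the assay and not a number. The step between them is an at least 1.2-fold higher number from compound 1 to compound 2 (0.09 log units; that floor lies within the scatter), so compound 2 stands at the weak end of the two results shown, its reading being (the limit of > 50000 nM in this assay, at which 1 of the 2 values shown sits).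

Compound 3 is `CC/C=C/C(=O)Nc1cccc(Oc2nc(Nc3ccc(OC)cc3)nc3c2CSCC3)c1`. Relative to compound 2 the change is 4-methoxyphenyl in place of 1-methyl-1H-pyrazol-3-yl on a nitrogen on an aromatic ring. Among the compounds with values here, the one measured step concerns the amide chain and not the nitrogen on the aromatic ring, so nothing measured bears on this change, and no direction beyond the scatter can be set for it. The step from compound 2 to compound 3 is therefore expected to be an at least 1.1-fold lower number from compound 2 to compound 3 (0.04 log units; that floor lies within the scatter). Compound 3 is estimated at 45000 nM in this assay. Compound 3 is expected to fall between 12000 nM and 150000 nM.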

Compound 3, half-maximal inhibitory concentration: 31400 nM
Estimate against measurement, compound 3: 1.4-fold (0.16 log units) above; low and high end bracket the measured number.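

Within the data shown here, replacing 1-methyl-1H-pyrazol-3-yl with 4-methoxyphenyl on a nitrogen on an aromatic ring gives, in this assay, an at least 1.5-fold lower number from compound 2 to compound 3 (0.20 log units; that floor lies within the scatter), and this is the first reading at this position, since the earlier step concerned only the amide chain. The swap of (1-methyl-1H-pyrazol-3-yl)amino for (4-methoxyphenyl)amino brings a measured number on the scale, with compound 3 at 31400 nM, yet the step gives no direction beyond the scatter. The reading of compound 2 is a limit and not a number, so the true size of this step cannot be fixed from the pair: the limit of > 50000 nM in this assay, at which 1 of the 3 values shown sits.

Still open, as far as these compounds go, is whether a change at this nitrogen can move the number clearly beyond the scatter, and whether the same swap would read alike on the amide chain of compound 1. Also open, from the compounds shown here alone, is how a plain phenyl or a 4-fluorophenyl on that nitrogen would read, or a dimethylamino group at the end of the amide chain.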